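Swapping Phenyl for Furan-3-yl on Three Inactive Compounds

This account rests on a few compounds, and the source may have more. Where it says the series, first, only, none or still open, it means among the compounds named here.

Compound 1, `COc1ncnc2c1c(-c1ccccc1)cn2[C@@H]1O[C@H](CO)[C@@H](O)[C@H]1O`, gives > 20000 nM in a functional assay on HCT-116 cells (Homo sapiens), read by MTT assay, with a stated time of 72 h (a higher number here means a weaker inhibitor, a lower number a stronger inhibitor), which is a limit of the assay rather than a number.
Compound 2, `CNc1ncnc2c1c(-c1ccccc1)cn2[C@@H]1O[C@H](CO)[C@@H](O)[C@H]1O`, gives > 100000 nM, again a limit.
Compound 3, `O=c1[nH]cnc2c1c(-c1cccs1)cn2[C@@H]1O[C@H](CO)[C@@H](O)[C@H]1O`, gives > 20000 nM, again a limit.

None of the three measured compounds shows a readable potency. Compound 2 sits at the limit of > 100000 nM in this assay, at which 1 of the 3 values shown sits. Compound 1 and compound 3 sit at the limit of > 20000 nM in this assay, at which 2 of the 3 values shown sit. Among the compounds with values here, the only single-point change among measured compounds, methylamino in place of methoxy on an aromatic carbon, is a step that the two limits leave unreadable from compound 1 to compound 2, so it teaches nothing about direction or size. Within the data shown here, compound 3 differs from compound 2 in more than one place, so no step between them can be read.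

The unmeasured compound 4, `CNc1ncnc2c1c(-c1ccoc1)cn2[C@@H]1O[C@H](CO)[C@@H](O)[C@H]1O`, differs from compound 2 by furan-3-yl in place of phenyl on an aromatic carbon. Among the measured compounds shown here, no measured step carries this change, and no measured step is readable at all, so there is nothing to anchor a prediction beyond the fact that every value so far is a limit. The expectation for compound 4 is therefore that it also fails to reach a measurable value, with a step of a number no higher from compound 2 to compound 4 (the limit leaves the size open) expected. The estimated value for compound 4 is 100000 nM, within 20000 nM to 300000 nM.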

Compound 4, half-maximal inhibitory concentration: > 20000 nM
Compound 4: no number, only a limit; the forecaster's own chance of this, stated with the estimate: 85%; the middle value is on the limit's open side.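

Compound 2 and compound 4 both give only a limit of the assay rather than a number, so the change from phenyl to furan-3-yl between them cannot be read, in either direction or size. The compounds shown leave open whether any of these groups on the shared core gives a measurable potency.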